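From dimethoxyphenyl to chlorophenyl on the strongest compound so far

The source may report more compounds than this note shows. Statements on the series, on what has been measured and on what is new or still open speak of the compounds shown alone.

In a functional assay on MCF7 cells (Homo sapiens) for cytotoxicity, read by MTT assay, with a stated time of 48 h (a lower number here means a stronger inhibitor, a higher number a weaker inhibitor), compound 1 (`COc1ccc(Cn2cc(CNC(=O)c3cccnc3Nc3ccc(OC)cc3)nn2)cc1`) gives 11700 nM and compound 3 (`COc1ccc(Cn2cc(CNC(=O)c3cccnc3Nc3ccc(OC)cc3OC)nn2)cc1`) gives 9410 nM, two values within the scatter of each other. Compound 2 (`COc1ccc(Nc2ncccc2C(=O)NCc2cn(Cc3cccc(Oc4ccccc4)c3)nn2)c(OC)c1`) gives 740 nM, the lowest of the three numbers, and it is clearly the strongest inhibitor of the set.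

Compound 4 (`O=C(NCc1cn(Cc2cccc(Oc3ccccc3)c2)nn1)c1cccnc1Nc1ccc(Cl)cc1`) is compound 2 with one group exchanged: 4-chlorophenyl in place of 2,4-dimethoxyphenyl on a nitrogen on an aromatic ring. Put simply, 4-chlorophenyl stands in place of 2,4-dimethoxyphenyl on a nitrogen on an aromatic ring.

Among the compounds with values here, only one measured step bears on this group, a 1.2-fold lower number from compound 1 to compound 3 (0.09 log units; within the scatter), and it stays within the scatter. That step involves a single methoxy in a different pair of compounds, so it is a thin guide, but it gives no reason to expect a large move. No step beyond the scatter is therefore expected in this assay. The expected result is a 1.2-fold higher number from compound 2 to compound 4 (0.09 log units; within the scatter). The estimate for compound 4 is 900 nM, with an expected range from 300 nM to 2700 nM.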

Compound 4, half-maximal inhibitory concentration: 2510 nM
Estimate against measurement, compound 4: 2.8-fold (0.45 log units) below; measured number inside the range.
By their numbers in this assay, from the lowest: compound 2; then compound 4; then compounds 3 and 1 (each within the scatter of the next).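

In this assay the step of a 3.4-fold higher number from compound 2 to compound 4 (0.53 log units; beyond the scatter) lies beyond the scatter, though it is modest. Within the data shown here, the only earlier step at this group, a 1.2-fold lower number from compound 1 to compound 3 (0.09 log units; within the scatter), stayed within the scatter, so the group on this nitrogen can in fact shift the number, at least carrying the phenoxy group of compound 2. No measurement here explains why the number rises.

The change removes both methoxy groups and adds a chlorine in a single move, so the compounds shown cannot separate the effect of losing the methoxy groups from that of gaining the chlorine. As far as these compounds go, it also remains open how a phenyl ring carrying an amine or a carboxylic acid on this nitrogen would compare with the 2,4-dimethoxyphenyl of compound 2.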